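Swapping 2-methoxyethyl for vinyl: what compound 3 may give

The source may report more compounds than this note shows. Statements on the series, on what has been measured and on what is new or still open speak of the compounds shown alone.

Measured so far:
compound 1, `Cc1ccc(C(=O)C2=C(O)C(=O)N(CC(C)O)C2c2ccc(C(C)C)cc2)cc1`: 101%
compound 2, `COCCCN1C(=O)C(O)=C(C(=O)c2ccc(C)cc2)C1c1ccc(C(C)C)cc1`: 111%

Going by the values given here, compound 2 stands with the larger of the two numbers in an assay on isolated protein for inhibition of annexin A2/S100-A10 (Homo sapiens), with a stated time of 5 min, tested at 50 uM (a higher number here means more inhibition at the concentration tested (going by the name of the read-out), a lower number less inhibition), yet the only measured step, a number 10 percentage points higher from compound 1 to compound 2 (within the scatter), lies within the scatter, so the two cannot be told apart. Compound 3, `C=CCN1C(=O)C(O)=C(C(=O)c2ccc(C)cc2)C1c1ccc(C(C)C)cc1`, differs from compound 2 as follows: vinyl in place of 2-methoxyethyl on a saturated chain carbon bound to an amide-type nitrogen in a ring. Among the compounds with values here, the one measured step concerns the same saturated chain carbon and was within the scatter, so no step beyond the scatter is expected in this assay. Compound 3 is therefore estimated at 100%, between 80% and 115%. The expected step is a number 11 percentage points lower from compound 2 to compound 3 (beyond the scatter).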

Compound 3, a percentage reported as inhibition, at one concentration (the size of the read-out at that concentration, not a potency): 105%
Beside the measured number, compound 3's estimate is 5 percentage points below it, within the range that was stated.
By their numbers in this assay, from the lowest: compounds 1, 3 and 2 (each within the scatter of the next).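

The new compound extends what this position has shown: at the saturated chain carbon bound to an amide-type nitrogen in a ring, a hydrocarbon group without oxygen, vinyl, gives no step beyond the scatter in this assay against either oxygen-bearing group (a number 6 percentage points lower from compound 2 to compound 3 (within the scatter); a number 4 percentage points higher from compound 1 to compound 3 (within the scatter)). Three different groups at this place now cannot be told apart at the one concentration tested. Nothing available explains this result.

As far as these compounds go, whether an amine, a carboxylic acid or a longer chain at this place would move the number remains open. The compounds shown also leave open what changes elsewhere on the shared core would do.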